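Swapping the halogenated ring for a plain benzyl group

The source may report more compounds than this note shows. Statements on the series, on what has been measured and on what is new or still open speak of the compounds shown alone.

Three compounds have been measured in a physicochemical assay for solubility, with a stated time of 18 h, at pH 7.4; a lower number here means a less soluble compound, a higher number a more soluble compound:

compound 1 `COc1ccc(F)cc1CNCCCNc1ccnc2cc(Cc3ccc(F)cc3Cl)ccc12` gives 4200 nM
compound 2 `c1ccc(Oc2ccc3c(NCCCNCc4ccco4)ccnc3c2)cc1` gives 14500 nM
compound 3 `Fc1ccc(Cc2ccc3c(NCCCNCc4ccco4)ccnc3c2)c(Cl)c1` gives 4200 nM

Compound 1 stands level with compound 3, the two together giving the lowest numbers of the three; compound 2 sits well above both, as the step of a 3.5-fold lower number from compound 2 to compound 3 (0.54 log units; beyond the scatter) shows. The other measured step, no change at the digits printed from compound 1 to compound 3 (within the scatter), touches a different part of the molecule and tells nothing about the ring now under consideration.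

Compound 4 `COc1ccc(F)cc1CNCCCNc1ccnc2cc(CCc3ccccc3)ccc12` is compound 1 with one change: benzyl in place of 2-chloro-4-fluorophenyl on a saturated chain carbon bound to an aromatic carbon. Within the data shown here, the step that bears on this is the one from compound 2 to compound 3, where a halogenated benzyl group arriving on the same aromatic carbon of the shared core lowered the number modestly. Compound 4 keeps a group of similar shape but without the halogens, so a modest rise in this assay is expected for compound 4 relative to compound 1, on the order of a 1.9-fold higher number from compound 1 to compound 4 (0.28 log units; within the scatter). The estimate for compound 4 is therefore 8000 nM, expected within 3500 nM to 18000 nM.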

Compound 4, solubility: 4200 nM
Compound 4: middle estimate off by 1.9-fold (0.28 log units), on the high side, within the range that was stated.
By their numbers in this assay, from the lowest: compounds 1, 3 and 4 (each within the scatter of the next); then compound 2.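

In this assay, no change at the digits printed from compound 1 to compound 4 (within the scatter), so exchanging 2-chloro-4-fluorobenzyl for phenethyl at this place leaves the number within the scatter. The earlier step, a 3.5-fold lower number from compound 2 to compound 3 (0.54 log units; beyond the scatter), replaced phenoxy with the halogenated group and could not show whether the chlorine and fluorine had to stay; this pair shows that both can go, together with the change to phenethyl, without a readable shift. Nothing available explains why the number holds steady here.

Losing the halogens and moving to phenethyl happen in a single step, so the compounds shown cannot separate the two changes, and opposing shifts from each could cancel. On these data alone, how an amine or a carboxylic acid on this ring would read in this assay also remains open.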